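Swapping a three-carbon ring for a sulfur-bearing group

The source may report more compounds than this note shows. Statements on the series, on what has been measured and on what is new or still open speak of the compounds shown alone.

The measured compounds and their values:
compound 1, `COc1cccc(NC(=O)c2nnn(Cc3ccccc3)c2N)c1`: > 50100 nM
compound 2, `COc1cccc(NC(=O)c2nnn(Cc3ccc(C4CC4)cc3)c2N)c1`: > 50100 nM

In a toxicity assay on Vero cells (Chlorocebus sabaeus) for inhibition (on this read-out higher numbers stand for an effect only at larger amounts of compound and lower numbers for an effect already at smaller amounts), compound 1 gives > 50100 nM, which is a limit of the assay rather than a number. In this assay compound 2 likewise gives > 50100 nM, again a limit. For the measured compounds named here, the one measured step, a step that the two limits leave unreadable from compound 1 to compound 2, therefore cannot be sized, since both ends rest on (the limit of > 50100 nM in this assay, at which 2 of the 2 values shown sit). Compound 3, `COc1cccc(NC(=O)c2nnn(Cc3ccc([S+](C)[O-])cc3)c2N)c1`, differs from compound 2 by a group of 3 heavy atoms (1 carbon, 1 oxygen, 1 sulfur; no ring) in place of a group of 3 heavy atoms (3 carbon; one three-membered non-aromatic ring of carbon only), on an aromatic carbon. Going by the values given here, no measured step bears on this change; the only step at hand is unreadable, and no other pair in the set involves this group. With both neighbours at the limit, compound 3 is expected to show no effect within the tested range, so the step that the limit leaves unreadable from compound 2 to compound 3 is expected to be none beyond the scatter. Compound 3 is estimated at 80000 nM, with a range of 30000 nM to 250000 nM.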

Compound 3, half-maximal effective concentration in the Vero assay: > 50100 nM
Compound 3: no number, only a limit (the forecaster's own chance of this, stated with the estimate: 85%); the middle value is on the limit's open side.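

Compound 1, compound 2 and compound 3 all give only a limit rather than a number, so no step between them can be read: the limit of > 50100 nM in the Vero assay, at which 3 of the 3 values shown sit.

In a physicochemical assay for lipophilicity, read by HPLC, measured as chromatographic lipophilicity, at pH 7.4 (on this read-out higher numbers stand for higher lipophilicity and lower numbers for lower lipophilicity), compound 2 gives 3.2 and compound 3 gives 1.3.

As far as these compounds go, what stays open is at what amount, if any, these compounds show an effect in the Vero assay.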